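Closing the Dimethoxy Pair into a Dioxane Ring

The compounds below may be only part of what the source reports. "The series", "measured", "known", "first", "only" and "open" are said of these compounds alone.

Of the compounds shown here, three built on one shared core have been measured in a functional assay on K562 cells (Homo sapiens) for antiproliferative activity, read by CellTiter-Glo and CCK-8 assay, with a stated time of 72 h; a higher number here means a weaker inhibitor of growth, a lower number a stronger inhibitor of growth. Compound 1 `CNc1nc(Nc2ccc(C)c([N+](=O)[O-])c2)ncc1C(=O)Nc1cc(NC(=O)c2ccc3c(c2)OCCO3)ccc1C` gives 320 nM in this assay. Compound 2 `CNc1nc(Nc2ccc(C)c(N)c2)ncc1C(=O)Nc1cc(NC(=O)c2cccc(OC)c2)ccc1C` gives 330 nM. Compound 3 `CNc1nc(Nc2ccc(C)c(N)c2)ncc1C(=O)Nc1cc(NC(=O)c2ccc(OC)c(OC)c2)ccc1C` gives 380 nM. Compound 3 has the highest of the three numbers, yet its gap to compound 2 and its gap to compound 1 both sit within the usual scatter, so the three cannot be ranked. Within the data shown here, the only single-point step among them, a 1.2-fold higher number from compound 2 to compound 3 (0.06 log units; within the scatter), consists of methoxy in place of hydrogen on an aromatic carbon and changes nothing beyond the scatter.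

Compound 4 `CNc1nc(Nc2ccc(C)c(N)c2)ncc1C(=O)Nc1cc(NC(=O)c2ccc3c(c2)OCCO3)ccc1C` is the next step from compound 3: 2,3-dihydro-1,4-benzodioxin-6-yl in place of 3,4-dimethoxyphenyl on a carbonyl carbon. Among the measured compounds shown here, no measured pair isolates exactly this exchange. Compound 1 carries the same 2,3-dihydro-1,4-benzodioxin-6-yl group as compound 4 but also differs from compound 3 in its nitro rather than amino substituent, and its number and that of compound 3 lie within the scatter of each other. For the measured compounds named here, the one measured step, from compound 2 to compound 3, was itself flat. Compound 4 is therefore expected to show a 1.1-fold lower number from compound 3 to compound 4 (0.04 log units; within the scatter), that is no step beyond the scatter. The estimate for compound 4 is 350 nM, in a range from 170 nM to 720 nM.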

Compound 4, concentration for 50% growth inhibition: 320 nM
Compound 4: middle estimate off by 1.1-fold (0.04 log units), on the high side; measured number inside the range.
By their numbers in this assay, from the lowest: compounds 1, 4, 2 and 3 (each within the scatter of the next).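

In this assay, the exchange of 3,4-dimethoxyphenyl for 2,3-dihydro-1,4-benzodioxin-6-yl on a carbonyl carbon whose other neighbour is an amide-type nitrogen can now be read directly (a 1.2-fold lower number from compound 3 to compound 4 (0.07 log units; within the scatter)), and tying the two oxygens into a six-membered non-aromatic ring, with the heavy-atom count unchanged, gives no step beyond the scatter. The exchange of 3-methoxyphenyl for the same ring system also stays within the scatter (a 1.0-fold lower number from compound 2 to compound 4 (0.01 log units; within the scatter)), so the three groups tried at this position cannot be told apart in this assay. Among these compounds, compound 4 also gives the first direct reading of amino in place of nitro on an aromatic carbon (no change at the digits printed from compound 1 to compound 4 (within the scatter)), a second place where a single change stays within the scatter, though this rests on one pair only.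

On these data alone, whether a morpholine, a carboxylic acid or a longer chain in place of these aryl groups on the carbonyl carbon, or an acetamide in place of the amino group, would give a step beyond the scatter remains open. Nothing at hand bears on why these exchanges leave the numbers within the scatter of each other.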